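Fluoro for Hydrogen: Estimating the Cytotoxicity of Compound 4

This account rests on a few compounds, and the source may have more. Where it says the series, first, only, none or still open, it means among the compounds named here.

Compound 1 `Cc1ccc(-n2cc(COC(=O)c3c(C)nc4ccccc4c3-c3ccccc3)nn2)cc1` was tested in an ADME assay on J774.A1 cells (Mus musculus) for cytotoxicity, read by MTT assay, with a stated time of 48 h (on this read-out higher numbers stand for lower toxicity in this test and lower numbers for higher toxicity in this test), where compound 1 gives 39000 nM. Compound 3 `Cc1nc2ccc(Cl)cc2c(-c2ccccc2)c1C(=O)OCc1cn(Cc2ccc([N+](=O)[O-])cc2)nn1` gives 75000 nM in this assay; the two numbers lie within the scatter of repeated measurements, so neither compound can be called more or less toxic than the other. For compound 2 `COc1cccc(Cn2cc(COC(=O)c3c(C)nc4ccc(Cl)cc4c3-c3ccccc3)nn2)c1` the entry in this assay reads "not determined" (no result reported), so no number is available. Compound 1 thus holds the lower of the two available numbers, with compound 3 close to it.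

Compound 4 `Cc1ccc(-n2cc(COC(=O)c3c(C)nc4ccccc4c3-c3ccccc3)nn2)cc1F` has not yet been measured. It differs from compound 1 by fluoro in place of hydrogen on an aromatic carbon. For the measured compounds named here, no measured pair in this set shows a change of this kind, so the size of the step rests on expectation alone. The change adds one fluorine, no ring, no donors, no acceptors and no net charge, and the step of a 1.0-fold higher number from compound 1 to compound 4 (0.01 log units; within the scatter) is expected to be small, in no particular direction, within the usual scatter. Compound 4 is therefore estimated to give 40000 nM in this assay, with a range from 15000 nM to 100000 nM.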

Compound 4, half-maximal cytotoxic concentration: 36000 nM
Compound 4: the middle estimate sits 1.1-fold (0.05 log units) above what was measured, within the range that was stated.
By their numbers in this assay, from the lowest: compounds 4, 1 and 3 (each within the scatter of the next, the first and the last beyond it).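

Fluoro in place of hydrogen, turning 4-methylphenyl into 3-fluoro-4-methylphenyl, gives the first measured step between two compounds that differ in one place: in this assay it is a 1.1-fold lower number from compound 1 to compound 4 (0.03 log units; within the scatter) for this change. At this aromatic carbon, ortho to a methyl group and meta to a large group, a single fluorine therefore produces no difference that can be told from repeated measurement. Nothing available here offers an explanation for this result.

Going by these compounds, whether a larger or differently built group at the same carbon, such as chloro, methoxy, an amine or a carboxylic acid, would also stay within the scatter remains open. So does the outcome of fluoro on the other carbons of this ring or on the shared core.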